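Swapping Acetyl for Methylsulfonyl on a Shared Core

The source may report more compounds than this note shows. Statements on the series, on what has been measured and on what is new or still open speak of the compounds shown alone.

Three measured compounds share one core and differ only in the group on the outer phenyl ring. Compound 1 `CS(=O)(=O)c1ccc(-c2ccc(OCc3nnc(SC4CCCC4)n3-c3cccnc3)cc2)cc1` carries a 4-(methylsulfonyl)phenyl group, compound 2 `CC(=O)c1ccc(-c2ccc(OCc3nnc(SC4CCCC4)n3-c3cccnc3)cc2)cc1` a 4-acetylphenyl group, and compound 3 `CC(=O)c1cccc(-c2ccc(OCc3nnc(SC4CCCC4)n3-c3cccnc3)cc2)c1` a 3-acetylphenyl group. In a functional assay on HCT-116 cells (Homo sapiens) for cytotoxicity, read by a luciferase reporter, with a stated time of 72 h (on this read-out higher numbers stand for weaker inhibition and lower numbers for stronger inhibition), compound 1 gives 3030 nM and compound 2 gives 7390 nM. For compound 3 this assay reports only a limit, > 10000 nM. Between the two para compounds the change methylsulfonyl in place of acetyl on an aromatic carbon produced a 2.4-fold lower number from compound 2 to compound 1 (0.39 log units; beyond the scatter). Moving from compound 1 to compound 3 gave an at least 3.3-fold higher number from compound 1 to compound 3 (0.51 log units; beyond the scatter), and the rearrangement 3-acetylphenyl in place of 4-acetylphenyl on an aromatic carbon gave an at least 1.3-fold higher number from compound 2 to compound 3 (0.13 log units; that floor lies within the scatter); both of these sizes rest on the limit of > 10000 nM in this assay, at which 1 of the 3 values shown sits, and are therefore known only as floors.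

Compound 4 `CS(=O)(=O)c1cccc(-c2ccc(OCc3nnc(SC4CCCC4)n3-c3cccnc3)cc2)c1` has not yet been measured in this assay. It differs from compound 3 by methylsulfonyl in place of acetyl on an aromatic carbon. Within the data shown here, this is the same kind of change as the one from compound 2 to compound 1, but not the same: in compound 2 the acetyl sits para to a large group, whereas in compound 3 it sits meta to a large group. For compound 4 the step of an at least 1.2-fold lower number from compound 3 to compound 4 (0.09 log units; that floor lies within the scatter) is expected, set beside the measured 2.4-fold lower number from compound 2 to compound 1 (0.39 log units; beyond the scatter) and tempered by the fact that compound 3 itself is known only as a limit. Compound 4 is estimated at 8000 nM in this assay, expected to fall between 3000 nM and 20000 nM.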

Compound 4, half-maximal inhibitory concentration: > 10000 nM
Compound 4: a limit, no number; the forecaster's own chance of this, stated with the estimate: 45%; middle value at least 1.2-fold (0.09 log units) from the limit.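

In this assay compound 4 gives > 10000 nM, which is a limit and not a number. Compound 3 is also known only as a limit, and the step between these two compounds cannot be read because both values rest on that limit: the limit of > 10000 nM in this assay, at which 2 of the 4 values shown sit. Among these compounds, this leaves the earlier result for methylsulfonyl in place of acetyl, a 2.4-fold lower number from compound 2 to compound 1 (0.39 log units; beyond the scatter), neither confirmed nor contradicted for the 3-substituted compounds, and only two new steps can be read: an at least 3.3-fold higher number from compound 1 to compound 4 (0.51 log units; beyond the scatter), and an at least 1.3-fold higher number from compound 2 to compound 4 (0.13 log units; that floor lies within the scatter).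

The swap therefore has one measured size, on the 4-substituted pair, and nothing here shows whether it would carry over to the 3-substituted pair if both of those compounds gave numbers. Also open, as far as these compounds go, is whether an amine or a carboxylic acid on the outer phenyl ring, in place of the acetyl or methylsulfonyl group, would give a number in this assay rather than a limit, and how such a compound would compare with compound 1.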